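Ear inhibition series: dichlorination of the thioether phenyl

A few compounds are considered here, and "the series" means these few. Any claim that something is new, unique, unknown or untested is made for them only; others in the source may bear on it.

Measured compounds:
compound 1 `COc1ccc(CCCCOc2ccc(CSc3ccccc3)nc2/C=C/C(=O)O)cc1` — 26%
compound 2 `COc1ccc(CCCCCCCCOc2ccc(CSCc3cccc(C(=O)O)c3)nc2/C=C/C(=O)O)cc1` — 0%

Both compounds were tested in a functional assay on the whole organism (Ear) for inhibition, with Mus musculus as the target, at a dose of 50 mg/kg by the oral route; on this read-out lower numbers stand for less inhibition and higher numbers for more inhibition at the one dose given (going by the name of the read-out). Compound 1 gives 26% and stands highest of the two numbers; compound 2 gives 0%, which lies beyond the usual scatter below compound 1. Within the data shown here, no single-point comparison exists between these two, so the pair shows only that the inhibition number of compound 1 is the higher of the two in this assay.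

Compound 3 `COc1ccc(CCCCOc2ccc(CSc3c(Cl)cccc3Cl)nc2/C=C/C(=O)O)cc1` has not yet been measured. It differs from compound 1 by 2,6-dichlorophenyl in place of phenyl on a sulfur. Among the measured compounds shown here, no measured pair in this set isolates this change, so its size in this assay is unknown. The step from compound 1 to compound 3 is expected to be small, a number 4 percentage points higher from compound 1 to compound 3 (within the scatter), possibly within the scatter. Compound 3 is therefore expected to give about 30%, with a range from 5% to 55%.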

Compound 3, a percentage reported as inhibition, in the whole organism at one dose (the size of the read-out at that dose, not a potency): 54%
Compound 3: the middle estimate sits 24 percentage points below what was measured, and the stated range covers the measured number.
By their numbers in this assay, from the lowest: compound 2; then compound 1; then compound 3.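

In this assay, among these compounds, the exchange of phenyl for 2,6-dichlorophenyl on a sulfur gives a number 28 percentage points higher from compound 1 to compound 3 (beyond the scatter) and is the first change that can be read at a single place. The read-out therefore responds to the group on this sulfur while the rest of the core of compound 1 stays the same. Nothing measured on these compounds accounts for the rise.

The compounds shown leave open whether a single chlorine on the phenyl ring would give a similar step, and whether 2,6-difluorophenyl or 2,6-dimethylphenyl would do the same. They also leave open whether the step persists when the 2,6-dichlorophenyl group is combined with a longer chain or a carboxylic acid elsewhere on the core.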